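This account rests on a few compounds, and the source may have more. Where it says the series, first, only, none or still open, it means among the compounds named here.

Three compounds sharing one core were tested in a functional assay on HeLa cells (Homo sapiens) for antiproliferative activity, read by MTT assay, with a stated time of 48 h; a higher number here means a weaker inhibitor, a lower number a stronger inhibitor. Compound 1 `O=[N+]([O-])c1cccc(-c2nn(-c3ccccc3)cc2C(Nc2nc3ccccc3s2)c2c(O)ccc3ccccc23)c1` gave 8220 nM, compound 2 `COc1ccc(-c2nn(-c3ccccc3)cc2C(Nc2nc3ccccc3s2)c2c(O)ccc3ccccc23)cc1` gave 9340 nM, and compound 3 `COc1ccc(-c2nn(-c3ccccc3)cc2C(Nc2nc3ccc(OC)cc3s2)c2c(O)ccc3ccccc23)cc1` gave 9240 nM. Between compound 2 and compound 1 the change is 3-nitrophenyl in place of 4-methoxyphenyl on an aromatic carbon, and it produced a 1.1-fold lower number from compound 2 to compound 1 (0.06 log units; within the scatter). The cores of compound 2 and compound 3 differ by methoxy in place of hydrogen on an aromatic carbon, which produced a 1.0-fold lower number from compound 2 to compound 3 (0.00 log units; within the scatter). Compound 4 `COc1ccc2nc(NC(c3cn(-c4ccccc4)nc3-c3cccc([N+](=O)[O-])c3)c3c(O)ccc4ccccc34)sc2c1` has not yet been measured. It differs from compound 3 by 3-nitrophenyl in place of 4-methoxyphenyl on an aromatic carbon, the same change that turned compound 2 into compound 1. In this assay the author expects a 1.1-fold lower number from compound 3 to compound 4 (0.05 log units; within the scatter), because the same change earlier gave a 1.1-fold lower number from compound 2 to compound 1 (0.06 log units; within the scatter) and the second change gave a 1.0-fold lower number from compound 2 to compound 3 (0.00 log units; within the scatter). Compound 4 is therefore estimated at 8300 nM, with a likely range from 4500 nM to 15500 nM.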

Compound 4, half-maximal inhibitory concentration: 6140 nM
Compound 4: middle estimate off by 1.4-fold (0.13 log units), on the high side; measured number inside the range.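

In this assay, 3-nitrophenyl in place of 4-methoxyphenyl gave a 1.5-fold lower number from compound 3 to compound 4 (0.18 log units; within the scatter), which agrees with the same change on the other core: the same change on two cores in this assay, a 1.1-fold lower number (0.06 log units; within the scatter) from compound 2 to compound 1 and a 1.5-fold lower number (0.18 log units; within the scatter) from compound 3 to compound 4, 1.3-fold (0.12 log units) apart, within the scatter of two such steps. Methoxy in place of hydrogen gave a 1.3-fold lower number from compound 1 to compound 4 (0.13 log units; within the scatter), and this too agrees with its earlier counterpart: the same change on two cores in this assay, a 1.0-fold lower number (0.00 log units; within the scatter) from compound 2 to compound 3 and a 1.3-fold lower number (0.13 log units; within the scatter) from compound 1 to compound 4, 1.3-fold (0.12 log units) apart, within the scatter of two such steps. Both changes therefore carried between these two cores without a gap beyond the scatter, but every step is itself within the scatter, so this does not show that a change with a clear effect would carry over in the same way.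

The compounds shown leave open whether an amine or a carboxylic acid in place of the methoxy would give a step beyond the scatter. They also leave open whether such a step would hold on both cores.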